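A few compounds are considered here, and "the series" means these few. Any claim that something is new, unique, unknown or untested is made for them only; others in the source may bear on it.

Compound 1 `CC(=O)NCc1ccc(-c2c3ncn(CC4(O)CCN(Cc5ccc(-c6ccco6)cc5Cl)CC4)c(=O)c3nn2C)cc1` gives 46.1 nM in an assay on isolated protein for inhibition of ubiquitin carboxyl-terminal hydrolase 7 (Homo sapiens), with stated times of 30 min and 2 h; a higher number here means a weaker inhibitor, a lower number a stronger inhibitor.
Compound 2 `Cn1nc2c(=O)n(CC3(O)CCN(Cc4ccc(-c5ccco5)cc4Cl)CC3)cnc2c1-c1ccc(OC(F)F)cc1` gives 179 nM in this assay.
Compound 3 `Cn1nc2c(=O)n(CC3(O)CCN(Cc4ccc(-c5cncs5)cc4Cl)CC3)cnc2c1-c1ccc(CN)cc1` gives 117 nM in this assay.

Among these three values in this assay, compound 3 holds the second highest number. Its nearest neighbour is compound 2, and the gap between those two values lies within the scatter, so no order between them can be claimed. Compound 1 lies further off, and that gap is beyond the scatter. Compound 4 `Cn1nc2c(=O)n(CC3(O)CCN(Cc4ccc(-n5cccn5)cc4Cl)CC3)cnc2c1-c1ccc(CN)cc1` has not yet been measured. It differs from compound 3 in one place: 1H-pyrazol-1-yl in place of 1,3-thiazol-5-yl on an aromatic carbon. Among the measured compounds shown here, the one measured step, a 3.9-fold higher number from compound 1 to compound 2 (0.59 log units; beyond the scatter), alters the ring that carries the acetamidomethyl group, not the ring that carries the chloro group, and so it does not bear directly on this exchange. For the measured compounds named here, no measured pair shows what swapping one five-membered aromatic ring with two hetero atoms for another does at this place. With nothing to lean on, the change from compound 3 to compound 4 is expected to produce no step beyond the scatter in this assay. The expected step is a 1.0-fold higher number from compound 3 to compound 4 (0.01 log units; within the scatter). Compound 4 is therefore estimated at 120 nM, with a range from 60 nM to 240 nM.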

Compound 4, half-maximal inhibitory concentration: 233 nM
Compound 4: middle estimate off by 1.9-fold (0.29 log units), on the low side; the range from low to high includes it.
By their numbers in this assay, from the lowest: compound 1; then compounds 3, 2 and 4 (each within the scatter of the next).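

In this assay, among the compounds shown here, the first matched pair at this place, on the six-membered aromatic ring that carries the chloro group, shows a 2.0-fold higher number from compound 3 to compound 4 (0.30 log units; within the scatter) when 1H-pyrazol-1-yl takes the place of 1,3-thiazol-5-yl. Within this pair, a five-membered aromatic ring holding one nitrogen and one sulfur and one holding two nitrogens, with the same count of heavy atoms, cannot be told apart, and this reading rests on compound 3 and compound 4 alone. Nothing available here explains the step or ties it to any property of either ring.

What a pyridine ring, a morpholine or a simple methoxy group would give at this place stays open, since all the groups shown here are five-membered aromatic rings with two hetero atoms or lie elsewhere in the molecule. Also open, from the compounds shown here alone, is whether the same exchange would read alike with the acetamidomethyl group of compound 1 or the difluoromethoxy group of compound 2 on the other aromatic ring.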